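The compounds below may be only part of what the source reports. "The series", "measured", "known", "first", "only" and "open" are said of these compounds alone.

Compound 1 `Cc1ccccc1CN1CCc2c(sc(NC(=O)c3ccccc3Cl)c2C(N)=O)C1` in a functional assay on HL-60 cells (Homo sapiens) for antiproliferative activity, with a stated time of 24 h (a lower number here means a stronger inhibitor, a higher number a weaker inhibitor), gives only a limit, > 50000 nM, so where it truly stands is not known. Compound 2 `NC(=O)c1c(NC(=O)c2ccccc2Cl)sc2c1CCN(C(=S)Nc1ccccc1)C2` gives 5940 nM, and compound 3 `NC(=O)c1c(NC(=O)c2ccccc2Cl)sc2c1CCN(C(=S)Nc1cccc3ccccc13)C2` gives 13400 nM. The change from compound 1 to compound 4 `NC(=O)c1c(NC(=O)c2ccccc2Cl)sc2c1CCN(C(=S)Nc1cccnc1)C2` is a group of 9 heavy atoms (6 carbon, 2 nitrogen, 1 sulfur; one six-membered aromatic ring with 1 hetero atom) in place of a group of 8 heavy atoms (8 carbon; one six-membered aromatic ring of carbon only), on an amine nitrogen in a ring. The closest measured step is an at least 8.4-fold lower number from compound 1 to compound 2 (0.92 log units; beyond the scatter), which likewise puts a group of 9 heavy atoms with one six-membered aromatic ring on that amine nitrogen in a ring; it counts only as a floor because of the limit of > 50000 nM in this assay, at which 1 of the 3 values shown sits. The step of a 2.3-fold higher number from compound 2 to compound 3 (0.35 log units; beyond the scatter) shows that swapping the aromatic ring on the amide-type nitrogen moves the number only modestly. The expected step is therefore an at least 7.1-fold lower number from compound 1 to compound 4 (0.85 log units; beyond the scatter), toward a lower number. Compound 4 is estimated at 7000 nM, between 2500 nM and 25000 nM.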

Compound 4, half-maximal inhibitory concentration: 33900 nM
Estimate against measurement, compound 4: 4.8-fold (0.69 log units) below; the whole stated range lies below it.
By their numbers in this assay, from the lowest: compound 2; then compound 3; then compound 4. At a limit, above all of these: compound 1.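

On the amide-type nitrogen, pyridin-3-yl does worse in this assay than either carbon-only ring, giving a 5.7-fold higher number from compound 2 to compound 4 (0.76 log units; beyond the scatter) and a 2.5-fold higher number from compound 3 to compound 4 (0.40 log units; beyond the scatter). The aromatic ring at this position therefore matters more than compound 3 alone suggested, and the gain seen with compound 2 does not carry over in full to compound 4, where the step is an at least 1.4-fold lower number from compound 1 to compound 4 (0.16 log units; that floor lies within the scatter). That floor cannot show a real gain over compound 1 because its value is only a limit: the limit of > 50000 nM in this assay, at which 1 of the 4 values shown sits.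

Still open, from the compounds shown here alone, is where compound 1 truly stands. Also open, going by these compounds, is whether pyridin-4-yl or 4-methoxyphenyl on the amide-type nitrogen would stay close to phenyl or fall toward pyridin-3-yl.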